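Notes on the step from compound 2 to compound 3

This account rests on a few compounds, and the source may have more. Where it says the series, first, only, none or still open, it means among the compounds named here.

In an ADME assay on HEK293 cells (Homo sapiens) for cytotoxicity, read by CCK-8 assay, with a stated time of 48 h (on this read-out lower numbers stand for stronger inhibition and higher numbers for weaker inhibition), compound 1 `COc1ccc(/C=C\c2cc(OC)c(OC)c(OC)c2)cc1OCc1ccc(CN2CCCCC2C(=O)O)cc1` gives > 50000 nM, which is a limit and not a number. Within the data shown here, compound 2 `COc1ccc(/C=C\c2cc(OC)c(OC)c(OC)c2)cc1OCc1ccc(CO)cc1` gives 37000 nM, the only actual number so far. Among the measured compounds shown here, the single measured step, at the same place, is an at least 1.3-fold lower number from compound 1 to compound 2 (0.13 log units; that floor lies within the scatter). The next change, to compound 3 `COc1ccc(/C=C\c2cc(OC)c(OC)c(OC)c2)cc1OCc1ccc(CN2CC[C@H](O)C2)cc1`, is 3-hydroxypyrrolidin-1-yl in place of hydroxy on a saturated chain carbon bound to an aromatic carbon, on a saturated chain carbon bound to an aromatic carbon. For the measured compounds named here, with only that small step from compound 1 as a guide, no shift beyond the scatter is expected in this assay. The expected step is a 1.2-fold lower number from compound 2 to compound 3 (0.09 log units; within the scatter). The estimate for compound 3 is 30000 nM, with an expected range of 10000 nM to 60000 nM.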

Compound 3, half-maximal inhibitory concentration: > 50000 nM
Compound 3: a limit, no number (the forecaster's own chance of this, stated with the estimate: 30%); middle value at least 1.6-fold (0.22 log units) from the limit.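

In this assay, the change at this place gives an at least 1.3-fold higher number from compound 2 to compound 3 (0.13 log units; that floor lies within the scatter), so a ring with a hydroxy group has not been shown to move the read-out beyond the scatter. Both values in the pair of compound 1 and compound 3 are limits, so that step cannot be read. Compound 1 and compound 3, with different rings at this place, meet the same ceiling: the limit of > 50000 nM in this assay, at which 2 of the 3 values shown sit.

Open, from the compounds shown here alone, is whether any group here gives a number clearly separated from the 37000 nM of compound 2. A simple amine such as dimethylamino, or a carboxylic acid on a longer chain, would test this.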